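The source may hold more compounds than are shown below. What is called first, only, known or untested is meant among the compounds shown, and "the series" means these compounds.

Among the measured compounds shown here, in a functional assay (aorta) with Oryctolagus cuniculus as the target (a higher number here means weaker binding, a lower number tighter binding), compound 2 `COc1cc(C(C)O)ccc1OCCCN1CCC(C(c2ccc(F)cc2)c2ccc(F)cc2)CC1` gives 10 nM, the lowest of the two numbers so far. Compound 1 `COc1cc(C(C)=O)ccc1OCCCN1CCC(C(C(N)=O)(c2ccc(F)cc2)c2ccc(F)cc2)CC1` gives 25.1 nM in this assay, a gap from compound 2 that lies beyond the usual scatter. Compound 3 `O=S(=O)(CCCN1CCC(C(c2ccc(F)cc2)c2ccc(F)cc2)CC1)c1ccccc1` is not yet measured. It differs from compound 2 in one place: phenylsulfonyl in place of 4-(1-hydroxyethyl)-2-methoxyphenoxy on a saturated chain carbon, three bonds along the chain from an amine nitrogen in a ring. For the measured compounds named here, no measured pair covers this change, so the expectation rests on the shared core alone. Compound 3 is expected to bind somewhat more weakly than compound 2, with a step of a 3.0-fold higher number from compound 2 to compound 3 (0.48 log units; beyond the scatter). The estimate for compound 3 in this assay is 30 nM, ranging from 6 nM to 200 nM.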

Compound 3, dissociation constant: 20 nM
The estimate for compound 3 lay 1.5-fold (0.18 log units) above the measured number; low and high end bracket the measured number.
By their numbers in this assay, from the lowest: compounds 2, 3 and 1 (each within the scatter of the next, the first and the last beyond it).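

In this assay, phenylsulfonyl and 4-(1-hydroxyethyl)-2-methoxyphenoxy cannot be told apart on this saturated chain carbon: the change gives a 2.0-fold higher number from compound 2 to compound 3 (0.30 log units; within the scatter). In this one pair, then, a group with 0 hydrogen-bond donors stands in for one with 1 without a change beyond the scatter. Nothing available explains this result. Going by these compounds, whether an amine, a carboxylic acid or a longer chain at this place would give a similar number stays open. So does whether phenylsulfonyl would behave alike on the core of compound 1.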